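A few compounds are considered here, and "the series" means these few. Any claim that something is new, unique, unknown or untested is made for them only; others in the source may bear on it.

Two measured compounds set the scene. Compound 1 `CCO/N=C/Nc1cc(Cl)c(O)c(Cl)c1` and compound 2 `C#CCc1c(Cl)cc(N/C=N/O)cc1Cl` share a core carrying two chlorine atoms and an oxime-like chain; in a physicochemical assay for lipophilicity, measured as octanol-water partition (a lower number here means a more polar compound, a higher number a more lipophilic compound), compound 1 gives 2.8, and compound 2 gives 2.8. On these numbers compound 2 stands level with compound 1, a difference that lies within the scatter of this assay, so neither can be called the more or less lipophilic of the two.

The next compound, compound 3 `C#CCc1c(Cl)cc(N/C=N/OCC#N)cc1Cl`, is not yet measured. It differs from compound 2 in one place: cyanomethyl in place of hydrogen on an oxygen. Read one bond further out, the change is hydroxy to cyanomethoxy.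

Within the data shown here, no measured pair here shows this particular change, so its effect in this assay has to be judged without a direct precedent. Starting from compound 2 at 2.8, the step of a number 0.30 log units higher from compound 2 to compound 3 (within the scatter) is expected to be small, at the edge of the scatter. Compound 3 is accordingly estimated at 3.1, within a range from 2.6 to 3.6.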

Compound 3, partition coefficient: 3
Estimate against measurement, compound 3: 0.10 log units above; the range from low to high includes it.
By their numbers in this assay, from the lowest: compounds 1, 2 and 3 (each within the scatter of the next).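

Cyanomethyl in place of hydrogen on an oxygen gives a number 0.20 log units higher from compound 2 to compound 3 (within the scatter) in this assay, the only step measured at this oxygen among these compounds. Read one bond further out as hydroxy to cyanomethoxy, the change replaces a hydrogen atom with a group of 3 heavy atoms that contains a triple bond, yet the step stays within the scatter. Nothing measured here accounts for the size of this step.

The compounds shown leave open whether a carboxylic acid or a longer chain ending in an amine on this oxygen would give a step beyond the scatter in this assay. Among these compounds, they also leave open whether the same change would give a similar step on a different core, as only one pair carries it.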